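Benzyl in Place of Methoxyphenyl: Expected Inhibition

A few compounds are considered here, and "the series" means these few. Any claim that something is new, unique, unknown or untested is made for them only; others in the source may bear on it.

Compound 1, `Cc1ccc(C(=O)CCc2nnc(-c3ccccc3Cl)o2)cc1`: 36.2%
Compound 2, `Cc1ccc(C(=O)CCc2nnc(-c3ccc(Cl)cc3)o2)cc1`: 62.7%
Compound 3, `COc1ccc(-c2nnc(CCC(=O)c3ccc(C)cc3)o2)cc1`: 69.3%

In a functional assay on the whole organism (strain Wistar) for inhibition, with Rattus norvegicus as the target, with stated times of 30 min and 2 h, at a dose of 20 mg/kg by the oral route (on this read-out lower numbers stand for less inhibition and higher numbers for more inhibition at the one dose given (going by the name of the read-out)), compound 3 gives the highest of the three numbers. Compound 2 sits close to it, with a number 6.6 percentage points higher from compound 2 to compound 3 (within the scatter), while compound 1 lies clearly lower, with a number 33.1 percentage points higher from compound 1 to compound 3 (beyond the scatter). Compound 4, `Cc1ccc(C(=O)CCc2nnc(Cc3ccccc3)o2)cc1`, differs from compound 3 by benzyl in place of 4-methoxyphenyl on an aromatic carbon. Among the compounds with values here, no measured step tests this kind of change: the steps of a number 26.5 percentage points higher from compound 1 to compound 2 (beyond the scatter) and a number 33.1 percentage points higher from compound 1 to compound 3 (beyond the scatter) only alter which group sits on the phenyl ring, and the phenyl ring itself is kept in every measured compound. Within the data shown here, since the entering benzyl carries no hydrogen-bond acceptor and no measured compound shows such a case, the expectation is uncertain and leans toward a loss. Compound 4 is expected to give 50%, within 30% to 70%. That estimate means an expected step of a number 19.3 percentage points lower from compound 3 to compound 4 (beyond the scatter).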

Compound 4, a percentage reported as inhibition, in the whole organism at one dose (the size of the read-out at that dose, not a potency): 24.7%
Beside the measured number, compound 4's estimate is 25.3 percentage points above it; the measured number lies below the stated range.
By their numbers in this assay, from the lowest: compound 4; then compound 1; then compounds 2 and 3 (each within the scatter of the next).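

In this assay, benzyl at this position gives less inhibition than each of the three phenyl groups it can be compared with: a number 44.6 percentage points lower from compound 3 to compound 4 (beyond the scatter), a number 38 percentage points lower from compound 2 to compound 4 (beyond the scatter) and a number 11.5 percentage points lower from compound 1 to compound 4 (beyond the scatter), all beyond the scatter. The earlier compounds shown here only varied the group carried on the phenyl ring, whereas this change replaces the phenyl group itself and gives the lowest number of the four. Nothing measured here explains this loss.

Still open, from the compounds shown here alone, is whether 4-methoxybenzyl, a longer chain such as 2-phenylethyl, or an amine at this position would restore inhibition.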